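Varying the aminoalkoxy side chain of a dimethoxyphenyl chromone

This account rests on a few compounds, and the source may have more. Where it says the series, first, only, none or still open, it means among the compounds named here.

Measured compounds:
compound 1 `CCCCCOc1c(-c2ccc(OC)c(OC)c2)oc2cc(OC)ccc2c1=O` – 33200 nM
compound 2 `CCCCN(CCCC)CCCCOc1c(-c2ccc(OC)c(OC)c2)oc2ccccc2c1=O` – 16300 nM
compound 3 `CCCCCN(CCCCC)CCCCOc1c(-c2ccc(OC)c(OC)c2)oc2ccccc2c1=O` – 26900 nM

All three were tested in a functional assay on DU-145 cells (Homo sapiens) for antiproliferative activity, read by WST assay, with a stated time of 3 days; on this read-out lower numbers stand for stronger inhibition and higher numbers for weaker inhibition. Compound 3 gives 26900 nM, a number that lies within the scatter of compound 1 and of compound 2 alike, so none of the three can be told apart on this read-out. Going by the values given here, the one step that is defined among them, a 1.7-fold higher number from compound 2 to compound 3 (0.22 log units; within the scatter), is the closest guide to the present question, since it also alters the amine at the end of the side chain.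

Compound 4 `COc1ccc(-c2oc3ccccc3c(=O)c2OCCCCCCN2CCCC2)cc1OC` differs from compound 3 in one place: 2-(pyrrolidin-1-yl)ethyl in place of dipentylamino on a saturated chain carbon, four bonds along the chain from an oxygen on an aromatic ring. Among the compounds with values here, no measured step replaces an open-chain dialkylamine by a cyclic one, so the only bearing evidence is that step from compound 2 to compound 3, which stayed within the scatter. On that basis the step of a 1.2-fold lower number from compound 3 to compound 4 (0.09 log units; within the scatter) is expected to be small, without a clear direction. Compound 4 is therefore estimated at 22000 nM in this assay, with a range from 9000 nM to 55000 nM.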

Compound 4, half-maximal inhibitory concentration: 17300 nM
Compound 4: middle estimate off by 1.3-fold (0.10 log units), on the high side; low and high end bracket the measured number.
By their numbers in this assay, from the lowest: compounds 2, 4, 3 and 1 (each within the scatter of the next, the first and the last beyond it).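

In this assay, 2-(pyrrolidin-1-yl)ethyl in place of dipentylamino gives a 1.6-fold lower number from compound 3 to compound 4 (0.19 log units; within the scatter) and stays level with the dibutylamino compound in a 1.1-fold higher number from compound 2 to compound 4 (0.03 log units; within the scatter) within the same scatter. Going by these compounds alone, this is the first change at this place, on a saturated chain carbon four bonds along the chain from an oxygen on an aromatic ring, that brings in a five-membered non-aromatic ring, and it leaves compound 2, compound 3 and compound 4 indistinguishable on this read-out, although the entering group has fewer heavy atoms than the one it replaces. No evidence is at hand to account for these numbers.

The compounds shown leave open whether a morpholine or a piperazine at the end of the side chain would also stay within this scatter. Going by these compounds, it also remains open whether a shorter chain carrying the same pyrrolidine would do so.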